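Benzyl ring substitution in the thienopyrimidinone series

This account rests on a few compounds, and the source may have more. Where it says the series, first, only, none or still open, it means among the compounds named here.

Compound 1: `COc1cccc(Cn2cnc3sc(-c4ccnc(N)c4)cc3c2=O)c1`, 18 nM
Compound 2: `Nc1cc(-c2cc3c(=O)n(Cc4cccc(F)c4)cnc3s2)ccn1`, 34 nM

Measured so far in an assay on isolated protein for inhibition of Rho-associated protein kinase 1 (Homo sapiens), read by radiometric assay and 33P incorporation, with a stated time of 40 min, in the presence of a further agent that is not named here (a lower number here means a stronger inhibitor, a higher number a weaker inhibitor), compound 2 gives the higher of the two numbers, and compound 1 the lower; the difference, a 1.9-fold higher number from compound 1 to compound 2 (0.28 log units; within the scatter), is within the scatter, so the two cannot be ranked. Compound 3 `COc1ccc(Cn2cnc3sc(-c4ccnc(N)c4)cc3c2=O)cc1` is not yet measured. Relative to compound 2 the change is 4-methoxyphenyl in place of 3-fluorophenyl on a saturated chain carbon bound to an aromatic nitrogen. Among the measured compounds shown here, the only step that bears on it is the exchange between compound 1 and compound 2, which swapped methoxy for fluoro on the same pendant ring and moved the number by less than the scatter. Compound 3 carries a methoxy again, so a number near compound 1 is expected, and no step beyond the scatter is expected from compound 2 to compound 3, a 1.4-fold lower number from compound 2 to compound 3 (0.13 log units; within the scatter). Compound 3 is therefore estimated at 25 nM, with a range of 10 nM to 70 nM.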

Compound 3, half-maximal inhibitory concentration: 1450 nM
Estimate against measurement, compound 3: 58-fold (1.76 log units) below; the whole stated range lies below it.
By their numbers in this assay, from the lowest: compounds 1 and 2 (each within the scatter of the next); then compound 3.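

In this assay the benzyl ring is far from indifferent to where its substituent stands: 4-methoxyphenyl in place of 3-methoxyphenyl gives an 81-fold higher number from compound 1 to compound 3 (1.91 log units; beyond the scatter) and 4-methoxyphenyl in place of 3-fluorophenyl gives a 43-fold higher number from compound 2 to compound 3 (1.63 log units; beyond the scatter) on the same core. The exchange of methoxy for fluoro on the earlier pair, a 1.9-fold higher number from compound 1 to compound 2 (0.28 log units; within the scatter), therefore says nothing about tolerance at the other ring position, and among these compounds the location of the methoxy counts for much more than the choice between methoxy and fluoro. Nothing available explains the loss.

The compounds shown leave open whether the drop belongs to the methoxy group specifically or to any group in that ring position. A 4-fluorophenyl or an unsubstituted phenyl on the same chain carbon would separate these two readings.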